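Methoxyethyl for Cyclopropyl on the Sulfonamide Nitrogen

A few compounds are considered here, and "the series" means these few. Any claim that something is new, unique, unknown or untested is made for them only; others in the source may bear on it.

Compound 1 `O=C(NO)c1ccc(CN(C2CC2)S(=O)(=O)c2cc(F)c(F)c(F)c2F)cc1` carries a cyclopropyl on its sulfonamide nitrogen. Going by the values given here, in a functional assay on MM1.S cells (Homo sapiens) for inhibition, with a stated time of 72 h (on this read-out higher numbers stand for weaker inhibition and lower numbers for stronger inhibition), compound 1 gives 480 nM, the lowest of the two numbers measured so far. Compound 2 `CC(C)N(Cc1ccc(C(=O)NO)cn1)S(=O)(=O)c1cc(F)c(F)c(F)c1F` differs from compound 1 in several places; in this assay compound 2 gives 1600 nM, a higher number that lies beyond the usual scatter. Compound 3 `COCCN(Cc1ccc(C(=O)NO)cc1)S(=O)(=O)c1cc(F)c(F)c(F)c1F` has not yet been measured. It differs from compound 1 in a single place: 2-methoxyethyl in place of cyclopropyl on a sulfonamide nitrogen. Among the compounds with values here, no step between measured compounds covers this change, so nothing in the data points to its direction. The step is therefore expected to stay within the usual scatter, with at most a slight shift toward a higher number. Compound 3 is estimated at 700 nM in this assay, with a range from 250 nM to 2000 nM, which corresponds to an expected step of a 1.5-fold higher number from compound 1 to compound 3 (0.16 log units; within the scatter).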

Compound 3, half-maximal inhibitory concentration: 710 nM
The estimate for compound 3 lay 1.0-fold (0.01 log units) below the measured number, within the range that was stated.
By their numbers in this assay, from the lowest: compounds 1 and 3 (each within the scatter of the next); then compound 2.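

In this assay, 2-methoxyethyl in place of cyclopropyl on the sulfonamide nitrogen gives a 1.5-fold higher number from compound 1 to compound 3 (0.17 log units; within the scatter), the only single-place step at this position among the compounds shown. On this read-out, the position therefore accepts an open chain carrying an oxygen where compound 1 has a three-membered carbon ring, so in this pair the ring is not needed to keep the number within the scatter. Nothing measured here speaks to the reason for this outcome.

Going by these compounds, it remains open whether the oxygen of the 2-methoxyethyl matters at all, which a plain butyl chain would test, and whether a longer ether chain, a dimethylaminoethyl group or a carboxylic acid on this nitrogen would be accepted as well. Compound 2 differs from both other compounds in more than one place, so it cannot settle these questions.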